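A few compounds are considered here, and "the series" means these few. Any claim that something is new, unique, unknown or untested is made for them only; others in the source may bear on it.

Compound 1 `Cc1ccc(Nc2ncc(C(F)(F)F)c(N3Cc4cccc(N(C)S(C)(=O)=O)c4C3)n2)cc1C`: in an assay on Sf9 cells for inhibition of tyrosine-protein kinase receptor UFO (Homo sapiens), read by luminescence and ADP-Glo (a lower number here means a stronger inhibitor, a higher number a weaker inhibitor), compound 1 gives > 20000 nM, a limit of the assay.
Compound 2 `Cc1cc(Cl)ccc1Nc1ncc(C(F)(F)F)c(N2Cc3cccc(N(C)S(C)(=O)=O)c3C2)n1`: in this assay compound 2 gives > 20000 nM, also a limit.

Compound 2 therefore stands at the limit of this assay, the same position held by every value shown (the limit of > 20000 nM in this assay, at which 2 of the 2 values shown sit). Compound 3 `CN(c1cccc2c1CN(c1nc(Nc3cc(Cl)cc(C(F)(F)F)c3)ncc1C(F)(F)F)C2)S(C)(=O)=O` differs from compound 2 by 3-chloro-5-(trifluoromethyl)phenyl in place of 4-chloro-2-methylphenyl on a nitrogen on an aromatic ring. Among the compounds with values here, the single measured step, a step that the two limits leave unreadable from compound 1 to compound 2, also exchanged the group on that nitrogen, yet its size cannot be read, since both of its values are limits. No readable step bears on this change, so no direction beyond the scatter can be expected. Compound 3 is expected to give 30000 nM (range 8000 nM to 100000 nM), a step that the limit leaves unreadable from compound 2 to compound 3, most likely reported again only as a limit.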

Compound 3, half-maximal inhibitory concentration: > 30000 nM
Compound 3: only a limit was reported; the forecaster's own chance of this, stated with the estimate: 80%; the middle value lies on the limit itself.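

In this assay compound 3 gives > 30000 nM, again a limit, so the steps to it from compound 1 and compound 2 cannot be read. The compounds shown leave open whether exchanging the group on that nitrogen changes inhibition at all.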